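Compound 3 and the swap to a pentyl ester chain

This account rests on a few compounds, and the source may have more. Where it says the series, first, only, none or still open, it means among the compounds named here.

Measured in a functional assay for inhibition; a higher number here means a weaker inhibitor, a lower number a stronger inhibitor:
- compound 1 `CC(C)(C)c1cc(-c2cc(=O)c3ccc(OCc4ccc(Cl)cc4)cc3o2)cc(C(C)(C)C)c1O`: 7000 nM
- compound 2 `CC(C)(C)c1cc(-c2cc(=O)c3ccc(O)cc3o2)cc(C(C)(C)C)c1O`: 1000 nM
- compound 3 `CC(C)(C)c1cc(-c2cc(=O)c3ccc(OCC(O)CO)cc3o2)cc(C(C)(C)C)c1O`: 100 nM

Compound 3 has the lowest number of the three in this assay, with compound 2 nearest to it and compound 1 furthest away. Compound 4 `CCCCCOC(=O)COc1ccc2c(=O)cc(-c3cc(C(C)(C)C)c(O)c(C(C)(C)C)c3)oc2c1` keeps the shared core, but pentyloxycarbonyl takes the place of 1,2-dihydroxyethyl on a saturated chain carbon bound to an oxygen on an aromatic ring: pentyloxycarbonyl in place of 1,2-dihydroxyethyl on a saturated chain carbon bound to an oxygen on an aromatic ring. Among the measured compounds shown here, two measured steps bear on this. Where 1,2-dihydroxyethyl replaced 4-chlorophenyl at that same place, the large step was a 70-fold lower number from compound 1 to compound 3 (1.85 log units; beyond the scatter). Where 2,3-dihydroxypropyl replaced hydrogen on the oxygen, the modest step was a 10-fold lower number from compound 2 to compound 3 (1.00 log units; beyond the scatter). For the measured compounds named here, no measured compound carries an ester chain, so both steps are only a rough guide. Removing 1,2-dihydroxyethyl is expected to give back part of that gain, a modest rise rather than a large one. The expected change is an 8.0-fold higher number from compound 3 to compound 4 (0.90 log units; beyond the scatter). The estimate for compound 4 is 800 nM, with an expected range from 200 nM to 4000 nM.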

Compound 4, half-maximal inhibitory concentration: 5000 nM
Compound 4: middle estimate off by 6.3-fold (0.80 log units), on the low side; the measured number lies above the stated range.
By their numbers in this assay, from the lowest: compound 3; then compound 2; then compounds 4 and 1 (each within the scatter of the next).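

In this assay, a 50-fold higher number from compound 3 to compound 4 (1.70 log units; beyond the scatter) shows that the gain seen with 2,3-dihydroxypropyl on this oxygen does not carry over to a non-aromatic chain of any kind, as (pentyloxycarbonyl)methyl loses it. With a 5.0-fold higher number from compound 2 to compound 4 (0.70 log units; beyond the scatter), this chain also stands on the weaker side of plain hydrogen on the oxygen, so 4-chlorobenzyl is no longer the only substituent shown to do so. With a 1.4-fold lower number from compound 1 to compound 4 (0.15 log units; within the scatter), the pentyl ester chain and the 4-chlorobenzyl group cannot be told apart in this assay, although they share no ring. Nothing shown here accounts for these differences.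

The compounds shown leave open whether the hydroxyl groups, the chain length or the ester carbonyl decides the outcome. A 2-hydroxyethyl chain, a methyl ester or a carboxylic acid at this place would begin to separate these features.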